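Swapping One Hydroxyphenyl Arm on a Shared Pyridine-Free Core

The compounds below may be only part of what the source reports. "The series", "measured", "known", "first", "only" and "open" are said of these compounds alone.

Of the compounds shown here, three built on one shared core have been tested so far in an ADME assay on HEK293 cells (Homo sapiens) for cytotoxicity, read by CCK-8 assay, with a stated time of 4 days; a higher number here means a weaker inhibitor, a lower number a stronger inhibitor. Compound 1 `Oc1ccc(-c2cc(-c3cccc(O)c3)cc(-c3cccc(O)c3)n2)cc1` gives 1560 nM. Compound 3 `Oc1ccc(-c2cc(-c3ccccc3O)cc(-c3ccccc3O)n2)cc1` gives 6990 nM, the highest of the two plain numbers, sitting clearly above compound 1. For compound 2 `Oc1ccc(-c2cc(-c3cccc(O)c3)cc(-c3ccc(O)cc3)n2)cc1` this assay reports only a limit, > 50000 nM, not a number; this is the limit of > 50000 nM in this assay, at which 1 of the 3 values shown sits.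

Among the measured compounds shown here, the one measured step is an at least 32-fold higher number from compound 1 to compound 2 (1.50 log units; beyond the scatter), a large change in which the shift of a single hydroxyl from one position to another pushes the value past the measurable range.

Compound 4 `Oc1ccc(-c2cc(-c3cccc(O)c3)cc(-c3ccccc3O)n2)cc1` is the unmeasured compound. It differs from compound 3 by 3-hydroxyphenyl in place of 2-hydroxyphenyl on an aromatic carbon. For the measured compounds named here, no measured step covers exactly this change. What bears on it is the pair of values for compound 1 and compound 3: compound 1 carries two 3-hydroxyphenyl groups and compound 3 two 2-hydroxyphenyl groups, and compound 1 sits well below compound 3. Compound 4 carries one of each, so the expectation is a moderate decrease, roughly half of the gap between those two, as a 2.1-fold lower number from compound 3 to compound 4 (0.33 log units; beyond the scatter). Compound 4 is therefore estimated at 3300 nM, with a likely range from 1500 nM to 7500 nM.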

Compound 4, half-maximal inhibitory concentration: > 50000 nM
Compound 4: no number, only a limit (the forecaster's own chance of this, stated with the estimate: 5%); middle value at least 15-fold (1.18 log units) from the limit.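

In this assay, putting 3-hydroxyphenyl in place of 2-hydroxyphenyl on the ring carbon opposite the ring nitrogen gives an at least 7.1-fold higher number from compound 3 to compound 4 (0.85 log units; beyond the scatter), while the opposite swap on the other arm, 2-hydroxyphenyl in place of 3-hydroxyphenyl, gives an at least 32-fold higher number from compound 1 to compound 4 (1.50 log units; beyond the scatter). Compound 4 carries one arm of each kind, yet it does not fall between its two neighbours: both swaps raise the number, so among these compounds what one arm does depends on what the other arm carries, and a mixed compound cannot be read as the average of two matched ones. The step between compound 2 and compound 4 cannot be read, because both compounds stop at the same limit rather than at a number: the limit of > 50000 nM in this assay, at which 2 of the 4 values shown sit.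

As far as these compounds go, how far compound 2 and compound 4 lie past that limit stays open, so any order between them is unknown. Every arm shown carries a hydroxyl on a phenyl ring, which leaves open whether a methoxy group or an amine in that place on the arm opposite the ring nitrogen would keep compound 1's low number or lose it as these swaps did.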